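A few compounds are considered here, and "the series" means these few. Any claim that something is new, unique, unknown or untested is made for them only; others in the source may bear on it.

Measured in a functional assay on RS4-11 cells (Homo sapiens) for inhibition, read by CCK-8 assay, with a stated time of 48 h; on this read-out lower numbers stand for stronger inhibition and higher numbers for weaker inhibition:
- compound 1 `O=[N+]([O-])c1cccc(NC(=S)NCCNS(=O)(=O)c2ccc(-c3ccccc3OCc3ccccc3)s2)c1`: 11600 nM
- compound 2 `O=C(NCCNS(=O)(=O)c1ccc(-c2ccccc2OCc2ccccc2)s1)Nc1cccc([N+](=O)[O-])c1`: > 20000 nM (a limit of the assay, not a number)

Compound 2 offers no exact starting point, since its > 20000 nM is only a limit of the assay.

Compound 3 `O=S(=O)(NCCNC(=S)Nc1ccc(Cl)cc1)c1ccc(-c2ccccc2OCc2ccccc2)s1` has not yet been measured. Its change from compound 2 is a group of 10 heavy atoms (7 carbon, 1 nitrogen, 1 sulfur, 1 chlorine; one six-membered aromatic ring of carbon only) in place of a group of 12 heavy atoms (7 carbon, 2 nitrogen, 3 oxygen; one six-membered aromatic ring of carbon only), on an amine nitrogen. The (3-nitrophenyl)carbamoyl group leaves the amine nitrogen, and a group holding sulfur and chlorine takes its place.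

Going by the values given here, one measured step bears on this change: an at least 1.7-fold higher number from compound 1 to compound 2 (0.23 log units; that floor lies within the scatter). In that step, a group with sulfur gave way to one without it, so read in reverse it points towards a lower number for compound 3. Among the compounds with values here, the evidence is weak, however, and no measured compound carries chlorine. Compound 1, whose group also holds sulfur, gives 11600 nM, so only a modest move is expected in this assay.

The estimated change is an at least 2.0-fold lower number from compound 2 to compound 3 (0.30 log units; that floor lies within the scatter). For compound 3 the expected value is 10000 nM, with an estimated range of 4000 nM to 20000 nM.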

Compound 3, half-maximal inhibitory concentration: > 50000 nM
Compound 3 was reported as a limit (the forecaster's own chance of this, stated with the estimate: 30%); at least 5.0-fold (0.69 log units) between middle value and limit.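

In this assay, putting 4-chlorophenyl in place of 3-nitrophenyl on an amide-type nitrogen, with the rest of the molecule unchanged, gives an at least 4.3-fold higher number from compound 1 to compound 3 (0.63 log units; beyond the scatter). Going by these compounds alone, this is the first clear sign that the aromatic group at this place can change the read-out beyond the scatter, and the drop goes against the weak hint from the earlier pair that a group holding sulfur might help. Compound 3 is reported only as a limit of the assay, not as a number: the limit of > 50000 nM in this assay, at which 1 of the 3 values shown sits.

With limits on both sides, the step from compound 2 to compound 3 cannot be read, so holding sulfur in the linking group is plainly not enough on its own to give a measurable value.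

On these data alone, what remains open is whether the loss follows the chlorine or the place of the substituent on the ring, a question that a 3-chlorophenyl or a 4-nitrophenyl group on this nitrogen could separate. A plain phenyl group would show how much either substituent contributes at all.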